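Fixing one configuration in compound 2

The source may report more compounds than this note shows. Statements on the series, on what has been measured and on what is new or still open speak of the compounds shown alone.

Measured in a functional assay on A9L-m1 cells with A9 (Mus musculus) as the target; a lower number here means that less compound is needed, a higher number that more compound is needed for the effect:
- compound 1 `Clc1nccnc1C1CN2CCC1CC2`: 1590000 nM
- compound 2 `CCCCCCOc1nccnc1C1CN2CCC1CC2`: 520000 nM

Compound 2 has the lower number of the two. Compound 3 `CCCCCCOc1nccnc1[C@H]1CN2CCC1CC2` differs from it only in how it is drawn: the two compounds have the same atoms and bonds; at least one stereo element is drawn with a configuration in one of them and without one in the other: 1 of 3 stereo elements differ; a stereocentre at a saturated ring carbon is drawn without a configuration in compound 2 and R in compound 3. Among the measured compounds shown here, the only measured step, a 3.1-fold lower number from compound 1 to compound 2 (0.49 log units; beyond the scatter), exchanged one group for another and did not touch a configuration, so it gives little guide to size here. For the measured compounds named here, no measured pair yet shows what a drawn configuration does, so no step beyond the scatter is expected in this assay, and neither direction is favoured with confidence. Compound 3 is estimated at 400000 nM, with a range of 150000 nM to 1100000 nM. The expected change is a 1.3-fold lower number from compound 2 to compound 3 (0.11 log units; within the scatter).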

Compound 3, half-maximal effective concentration: 1730000 nM
Compound 3: middle estimate off by 4.3-fold (0.64 log units), on the low side; the whole stated range lies below it.
By their numbers in this assay, from the lowest: compound 2; then compounds 1 and 3 (each within the scatter of the next).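

In this assay, drawing the saturated ring carbon as R gives a 3.3-fold higher number from compound 2 to compound 3 (0.52 log units; beyond the scatter) with atoms and bonds unchanged. Among the compounds shown here, the earlier step exchanged one group for another, so this is the first sign that the configuration drawn at this carbon can alone go with a shift beyond the scatter. The only difference to point to is this: the fact that one of compounds 2 and 3 is drawn with a defined configuration and the other without, at the place where they differ.

As far as these compounds go, what the S configuration at this carbon would give remains open. So does whether an amine or a butyloxy chain in place of hexyloxy would behave the same way.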